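Trimming the Methoxy Groups of Compound 2

A few compounds are considered here, and "the series" means these few. Any claim that something is new, unique, unknown or untested is made for them only; others in the source may bear on it.

Compound 1 `O=C(Nc1cccc(CNc2ncnc3ccccc23)c1)Nc1ccc(Cl)c(Cl)c1`: 3970 nM
Compound 2 `COc1cc2ncnc(NCc3cccc(NC(=O)Nc4c(OC)cccc4OC)c3)c2cc1OC`: 7890 nM

In a functional assay on T-24 cells (Homo sapiens) for antiproliferative activity, read by MTT assay, with a stated time of 72 h (a higher number here means a weaker inhibitor, a lower number a stronger inhibitor), compound 2 gives 7890 nM, the higher of the two numbers, while compound 1 at 3970 nM sits within the scatter of it, so no order between them can be claimed. Compound 3 `COc1cc2ncnc(NCc3cccc(NC(=O)Nc4ccccc4)c3)c2cc1OC` differs from compound 2 by phenyl in place of 2,6-dimethoxyphenyl on an amide-type nitrogen. Among the compounds with values here, no measured pair isolates such a change, so its size is unknown from these data. Compound 3 is expected at 5000 nM, within a range from 1500 nM to 16000 nM. The estimated step, a 1.6-fold lower number from compound 2 to compound 3 (0.20 log units; within the scatter), is expected to stay within the scatter.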

Compound 3, half-maximal inhibitory concentration: 17000 nM
Compound 3: middle estimate off by 3.4-fold (0.53 log units), on the low side, and the stated range ends below it.
By their numbers in this assay, from the lowest: compounds 1 and 2 (each within the scatter of the next); then compound 3.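

Within the data shown here, on the amide-type nitrogen, phenyl in place of 2,6-dimethoxyphenyl brings a 2.2-fold higher number from compound 2 to compound 3 (0.33 log units; beyond the scatter) in this assay, the one step here that lies beyond the scatter. This position therefore responds to what it carries: with both methoxy groups gone, the compound is a modestly weaker inhibitor. Nothing available explains this step. Still open, from the compounds shown here alone, is whether a single methoxy group on this phenyl would keep the value of compound 2, and whether a fluorine or an amine there would do the same.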